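A few compounds are considered here, and "the series" means these few. Any claim that something is new, unique, unknown or untested is made for them only; others in the source may bear on it.

Series notes. Compound 1 `Nc1ncnn2c([C@@H]3O[C@H](CO)[C@@H](O)[C@H]3O)cc(C#CC3CC3)c12` is the reference point. In a functional assay on K562 cells (Homo sapiens) for antiproliferative activity, with a stated time of 72 h (a lower number here means a stronger inhibitor, a higher number a weaker inhibitor), compound 1 gives 40 nM, the lowest of the two numbers shown, with compound 3 the nearest. Compound 3 `Nc1ncnn2c([C@@H]3O[C@H](CO)[C@@H](O)[C@H]3O)cc(-c3ccc(F)cc3F)c12` gives 69700 nM in this assay. Compound 2 `Nc1ncnn2c([C@@H]3O[C@H](CO)[C@@H](O)[C@H]3O)cc(C#Cc3ccc(F)cc3)c12` gives > 100000 nM in this assay, which is a limit of the assay and not a number (the limit of > 100000 nM in this assay, at which 1 of the 3 values shown sits). Both measured steps away from compound 1 are large: an at least 2500-fold higher number from compound 1 to compound 2 (3.39 log units; beyond the scatter) and a 1700-fold higher number from compound 1 to compound 3 (3.24 log units; beyond the scatter). Between the two aryl compounds the gap is small: an at least 1.4-fold lower number from compound 2 to compound 3 (0.15 log units; that floor lies within the scatter).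

Compound 4 `COc1ccc(-c2cc([C@@H]3O[C@H](CO)[C@@H](O)[C@H]3O)n3ncnc(N)c23)cc1` is not yet measured. The change from compound 1 is 4-methoxyphenyl in place of 2-cyclopropylethynyl on an aromatic carbon. In kind this matches the step from compound 1 to compound 3, an aryl group sitting directly on the aromatic carbon in place of 2-cyclopropylethynyl, and the step from compound 1 to compound 2 points the same way. A large rise in this assay is therefore expected for compound 4, a 1300-fold higher number from compound 1 to compound 4 (3.10 log units; beyond the scatter). Compound 4 is estimated at 50000 nM, in the range 8000 nM to 150000 nM, with a real chance that only a limit is recorded.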

Compound 4, half-maximal inhibitory concentration: 76400 nM
Compound 4: middle estimate off by 1.5-fold (0.18 log units), on the low side, and the stated range covers the measured number.
By their numbers in this assay, from the lowest: compound 1; then compounds 3 and 4 (each within the scatter of the next). At a limit, above all of these: compound 2.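

The 4-methoxyphenyl result shows that the large loss against the cyclopropyl alkyne is not tied to the fluorinated ring of compound 3: a 1900-fold higher number from compound 1 to compound 4 (3.28 log units; beyond the scatter). In this assay, the two aryl groups set directly on this aromatic carbon cannot be told apart, one with fluorines and one with a methoxy group: a 1.1-fold higher number from compound 3 to compound 4 (0.04 log units; within the scatter). The comparison with the aryl alkyne rests on a limit of the assay and gives only a floor: an at least 1.3-fold lower number from compound 2 to compound 4 (0.11 log units; that floor lies within the scatter).

Still open, from the compounds shown here alone, is whether the low number of compound 1 depends on the cyclopropyl ring, the triple bond or both. A cyclopropyl group directly on the aromatic carbon, or a triple bond carrying a methyl group or a short hydroxyalkyl chain, would separate these possibilities.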